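Imidazoline to methylimidazole on a fused tetralin-type scaffold

The source may report more compounds than this note shows. Statements on the series, on what has been measured and on what is new or still open speak of the compounds shown alone.

Measured compounds in a functional assay on Urethra with Alpha-1A adrenergic receptor (Oryctolagus cuniculus) as the target; a lower number here means a smaller maximal response, a higher number a larger maximal response:
compound 1 `CC(=O)Nc1cccc2c1CCCC2c1c[nH]cn1` gives 70%;
compound 2 `CS(=O)(=O)Nc1cccc2c1CCCC2C1=NCCN1` gives 87%;
compound 3 `CS(=O)(=O)Nc1ccc(F)c2c1CCCC2c1c[nH]cn1` gives 64%.

Compound 2 stands highest of the three numbers in this assay; compound 1 lies beyond the scatter below it, and compound 3 lies still further below. Compound 4 `Cn1cnc(C2CCCc3c(NS(C)(=O)=O)cccc32)c1` has not been measured. It differs from compound 2 in one place: a group of 6 heavy atoms (4 carbon, 2 nitrogen; one five-membered aromatic ring with 2 hetero atoms) in place of a group of 5 heavy atoms (3 carbon, 2 nitrogen; one five-membered non-aromatic ring with 2 hetero atoms), on a saturated ring carbon. Compounds 1 and 3, which both carry an aromatic five-membered ring with two hetero atoms at the same position, give the two lower values, so a downward step beyond the scatter is expected for compound 4 in this assay. The step from compound 2 to compound 4 is estimated at a number 25 percentage points lower from compound 2 to compound 4 (beyond the scatter). Compound 4 is expected to give about 62%, in a range from 40% to 85%.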

Compound 4, largest response reached (reported as efficacy), in percent of the reference or control that the assay uses: 40%
Beside the measured number, compound 4's estimate is 22 percentage points above it, and the stated range covers the measured number.
By their numbers in this assay, from the lowest: compound 4; then compounds 3 and 1 (each within the scatter of the next); then compound 2.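

In this assay, going by these compounds alone, replacing the non-aromatic ring on the saturated ring carbon with 1-methyl-1H-imidazol-4-yl gives the first single-place comparison at this position, a large step of a number 47 percentage points lower from compound 2 to compound 4 (beyond the scatter). Compounds 1 and 3 also carry an aromatic ring there, but each differs from compound 2 in more than one place, so neither could isolate this change. No measurement here accounts for the size of the step.

Going by these compounds, it remains open how an imidazole without the methyl group would compare on the core of compound 2. On these data alone, whether a thiazole or an oxazole at this carbon would give a similar response also remains open.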